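The source may report more compounds than this note shows. Statements on the series, on what has been measured and on what is new or still open speak of the compounds shown alone.

Of the compounds shown here, three have so far been tested in an assay on isolated protein for inhibition of Ephrin type-B receptor 4 (Homo sapiens), read by HTRF, tested at 10 uM; a lower number here means less inhibition, a higher number more inhibition at the concentration tested (going by the name of the read-out). Compound 1 `COC[C@@H]1CCCN1C(=O)[C@@H]1CCCN1c1cc(Nc2cccc(OC)c2)nc(N)n1` gives 0%. Compound 2 `Clc1ccc2sc(CN3CCN(c4ncnc5c4CN(Cc4ccccc4)CC5)CC3)cc2c1` gives 0%. Compound 3 `CN(CCCn1ccnc1)C(=O)[C@@H]1CCCN1c1nccc(Nc2ccccc2)n1` gives 0%, level with compounds 1 and 2 at the digits reported, so none of the three stands apart from the others. Compound 4 `CN(C)CC(C)(C)CNC(=O)[C@@H]1CCCN1c1nccc(Nc2ccccc2)n1` has not yet been measured. It differs from compound 3 in one place: (2-((dimethylamino)methyl)-2-methylpropyl)amino in place of (3-(1H-imidazol-1-yl)propyl)(methyl)amino on a carbonyl carbon. Among the measured compounds shown here, no pair of measured compounds differs in only one place, so no measured step guides this change. Because compound 3 shows 0% and the other two measured compounds show the same, the expected step in this assay is no change at the digits printed from compound 3 to compound 4 (within the scatter), nothing beyond the scatter. Compound 4 is therefore estimated at 0%, within a range from 0% to 10%.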

Compound 4, a percentage reported as inhibition, at one concentration (the size of the read-out at that concentration, not a potency): 0%
Compound 4: middle estimate and measured number agree at the digits printed; low and high end bracket the measured number.
By their numbers in this assay, from the lowest: compounds 1, 2, 3 and 4 (each within the scatter of the next).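

In this assay, replacing the (3-(1H-imidazol-1-yl)propyl)(methyl)amino group on the carbonyl carbon with (2-((dimethylamino)methyl)-2-methylpropyl)amino gives no change at the digits printed from compound 3 to compound 4 (within the scatter). Exchanging a group that has a five-membered aromatic ring for one with no ring therefore leaves the reading unmoved, but with neither compound showing any inhibition, the step cannot reveal whether this position matters. No available evidence bears on this result. As far as these compounds go, it remains open whether any group on this carbonyl carbon can produce measurable inhibition. A carboxylic acid or a longer chain carrying a morpholine ring might read differently.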